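A few compounds are considered here, and "the series" means these few. Any claim that something is new, unique, unknown or untested is made for them only; others in the source may bear on it.

Measured compounds:
Compound 1 `COc1cc2c(Oc3ccc(NC(=O)c4cc(-c5ccc(C(F)(F)F)cc5)ccn4)cc3F)ccnc2cc1OCCCN1CCN(C)CC1` gives 330 nM in a functional assay on MKN-45 cells (Homo sapiens) for cytotoxicity, read by MTT assay, with a stated time of 72 h; a higher number here means a weaker inhibitor, a lower number a stronger inhibitor.
Compound 2 `COc1ccc(-c2ccnc(C(=O)Nc3ccc(Oc4ccnc5cc(OCCCN6CCN(C)CC6)c(OC)cc45)c(F)c3)c2)cc1` gives 250 nM in this assay.
Compound 3 `COc1cc2c(Oc3ccc(NC(=O)c4cc(-c5ccc(C(F)(F)F)cc5)ccn4)cc3F)ccnc2cc1OCCCN1CCCC1` gives 260 nM in this assay.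

Compound 4 `COc1ccc(-c2ccnc(C(=O)Nc3ccc(Oc4ccnc5cc(OCCCN6CCCC6)c(OC)cc45)c(F)c3)c2)cc1` has not yet been measured. Compound 4 differs from compound 3 by methoxy in place of trifluoromethyl on an aromatic carbon. For the measured compounds named here, the same change is the one that leads from compound 1 to compound 2, where it gave a 1.3-fold lower number from compound 1 to compound 2 (0.12 log units; within the scatter). The core of compound 3 differs from the core of compound 1 by pyrrolidin-1-yl in place of 4-methylpiperazin-1-yl on a saturated chain carbon, three bonds along the chain from an oxygen on an aromatic ring, a change that gave a 1.3-fold lower number from compound 1 to compound 3 (0.10 log units; within the scatter). Both changes so far left the numbers within the usual scatter, so the second occurrence of the change is expected to behave like the first. The step from compound 3 to compound 4 is estimated at a 1.3-fold lower number from compound 3 to compound 4 (0.11 log units; within the scatter), resting on a 1.3-fold lower number from compound 1 to compound 2 (0.12 log units; within the scatter). Compound 4 is therefore expected to give about 200 nM in this assay, most likely between 110 nM and 380 nM.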

Compound 4, half-maximal inhibitory concentration: 150 nM
Estimate against measurement, compound 4: 1.3-fold (0.12 log units) above; the measured number falls inside the stated range.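

In this assay, putting methoxy in place of trifluoromethyl gave a 1.7-fold lower number from compound 3 to compound 4 (0.24 log units; within the scatter), and putting pyrrolidin-1-yl in place of 4-methylpiperazin-1-yl gave a 1.7-fold lower number from compound 2 to compound 4 (0.22 log units; within the scatter). The methoxy change behaved alike on the two cores: the same change on two cores in this assay, a 1.3-fold lower number (0.12 log units; within the scatter) from compound 1 to compound 2 and a 1.7-fold lower number (0.24 log units; within the scatter) from compound 3 to compound 4, 1.3-fold (0.12 log units) apart, within the scatter of two such steps. For the compounds shown here, the pyrrolidin-1-yl change did too, but since every one of these steps is small, this shows only that neither change moved the number much on these two cores, not that a real effect carries from core to core: the same change on two cores in this assay, a 1.3-fold lower number (0.10 log units; within the scatter) from compound 1 to compound 3 and a 1.7-fold lower number (0.22 log units; within the scatter) from compound 2 to compound 4, 1.3-fold (0.12 log units) apart, within the scatter of two such steps.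

As far as these compounds go, it remains open whether other groups at the same places, such as a nitrile in place of methoxy or a morpholin-4-yl in place of pyrrolidin-1-yl, would give steps beyond the scatter.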